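The source may report more compounds than this note shows. Statements on the series, on what has been measured and on what is new or still open speak of the compounds shown alone.

In a functional assay on the whole organism (strain albino) for inhibition, with Rattus norvegicus as the target, read by paw edema, with stated times of 1 h and 3 h, at a dose of 100 umol/kg by the oral route (on this read-out lower numbers stand for less inhibition and higher numbers for more inhibition at the one dose given (going by the name of the read-out)), two compounds have been measured. Compound 1 `Cc1c(C(=O)N/N=C/c2ccc(N(C)C)cc2)no[n+]1[O-]` gives 19% in this assay. Compound 2 `O=C(N/N=C/c1ccc2no[n+]([O-])c2c1)c1cccnc1` gives 0% in this assay, the lowest of the two numbers, and the number for compound 1 lies above it by more than the usual scatter. Compound 3 `Cc1[nH]cnc1C(=O)N/N=C/c1ccc2no[n+]([O-])c2c1` has not yet been measured. It differs from compound 2 in one place: 5-methyl-1H-imidazol-4-yl in place of pyridin-3-yl on a carbonyl carbon. Within the data shown here, no pair of measured compounds shows this change, so its effect on paw edema inhibition has no direct precedent here. Given that compound 2 gives 0%, a low starting point, the step of a number 8 percentage points higher from compound 2 to compound 3 (within the scatter) is expected to be small and upward. Compound 3 is therefore estimated to give 8% in this assay, within a range from 0% to 25%.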

Compound 3, a percentage reported as inhibition, in the whole organism at one dose (the size of the read-out at that dose, not a potency): 31%
Compound 3: middle estimate off by 23 percentage points, on the low side; measured number above the stated range.
By their numbers in this assay, from the lowest: compound 2; then compound 1; then compound 3.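

In this assay the exchange of pyridin-3-yl for 5-methyl-1H-imidazol-4-yl on a carbonyl carbon gives a number 31 percentage points higher from compound 2 to compound 3 (beyond the scatter) and so shows that the group at this place, whose other neighbour on that carbon is an amide-type nitrogen, can decide the size of the read-out. The step leaves the heavy-atom count unchanged, yet it replaces a six-membered aromatic ring with 1 hetero atom by a five-membered aromatic ring with 2 hetero atoms and brings in 1 hydrogen-bond donor. Nothing measured here explains the rise.

On these data alone, it remains open whether the gain belongs to the five-membered ring, to its methyl or to its ring hydrogen. A 1H-imidazol-4-yl without the methyl, or an N-methylated imidazole, on this carbonyl carbon would separate these parts.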